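The compounds below may be only part of what the source reports. "The series", "measured", "known", "first", "only" and "open" are said of these compounds alone.

Compound 1 `Cc1nc(C(NC(=O)C(=O)Nc2ccc(Cl)cc2)C2CCCNC2)sc1CO`: 60200 nM
Compound 2 `Cc1nc(C(NC(=O)C(=O)Nc2ccc(Cl)cc2)C2CCCN2)sc1CCO`: 4900 nM

Both were tested in an ADME assay on TZM-b1 cells (Homo sapiens) for cytotoxicity, read by XTT assay, with a stated time of 3 days; on this read-out higher numbers stand for lower toxicity in this test and lower numbers for higher toxicity in this test. Compound 1 gives 60200 nM, and compound 2 gives 4900 nM, the lower of the two numbers; the gap between them lies beyond the usual scatter, so compound 2 is the more toxic of the pair in this assay. Compound 3 `Cc1nc(C(NC(=O)C(=O)Nc2ccc(Cl)cc2)C2CCCNC2)sc1CCO` has not yet been measured. It differs from compound 2 in one place: piperidin-3-yl in place of pyrrolidin-2-yl on a saturated chain carbon bound to an amide-type nitrogen and an aromatic carbon. Compound 3 thus carries the ring of compound 1 together with the chain of compound 2, and the two measured numbers do not separate what the ring contributes from what the chain contributes. The step from compound 2 to compound 3 in this assay is estimated as a 3.7-fold higher number from compound 2 to compound 3 (0.57 log units; beyond the scatter), upward toward lower toxicity, though a change within the scatter would not be surprising. Compound 3 is expected to give about 18000 nM in this assay, with a range from 5000 nM to 70000 nM.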

Compound 3, half-maximal cytotoxic concentration: 59400 nM
For compound 3 the middle estimate is 3.3-fold (0.52 log units) below the measured one, within the range that was stated.
By their numbers in this assay, from the lowest: compound 2; then compounds 3 and 1 (each within the scatter of the next).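

Replacing pyrrolidin-2-yl with piperidin-3-yl on the saturated chain carbon bound to an amide-type nitrogen and an aromatic carbon gives a 12-fold higher number from compound 2 to compound 3 (1.08 log units; beyond the scatter) in this assay, so this single ring change moves the compound clearly toward lower toxicity in this test. With the piperidin-3-yl ring held the same, hydroxymethyl in place of hydroxy on a saturated chain carbon bound to an aromatic carbon gives a 1.0-fold lower number from compound 1 to compound 3 (0.01 log units; within the scatter), so the chain change leaves no readable difference in this assay. No measurement shown here explains why the ring change matters so much.

Going by these compounds, whether a smaller azetidine ring or an open-chain amine at this carbon would sit nearer compound 2 or compound 3 remains open. So does the outcome of placing a carboxylic acid or a longer chain on the hydroxy-bearing side.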